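Swapping a Propyl Chain for a Cyclopropyl Ring

The source may report more compounds than this note shows. Statements on the series, on what has been measured and on what is new or still open speak of the compounds shown alone.

On these data alone, compound 3 `CCCN1Cc2cc(OCc3cccc(-c4ccc(Cl)c(C(=O)O)c4)c3)ccc2C1=O` has no reported number in an assay on HEK293 cells for positive allosteric modulation of metabotropic glutamate receptor 2 (Rattus norvegicus), read by thallium flux (a lower number here means a smaller maximal response, a higher number a larger maximal response), where its entry reads "not determined" (no result reported), so its standing is unknown. Compound 4 `O=C(O)c1cc(-c2cccc(COc3ccc4c(c3)CN(C3CC3)C4=O)c2)ccc1Cl` differs from it in one place: cyclopropyl in place of propyl on an amide-type nitrogen in a ring. Two measured compounds offer a comparison of groups on the same nitrogen. Compound 1 `O=C(O)c1cc(-c2cccc(COc3ccc4c(c3)CN(C3CCCCC3)C4=O)c2)ccc1Cl` gives 63.3% in this assay, and compound 2 `CC(C)N1Cc2cc(OCc3cccc(-c4ccc(Cl)c(C(=O)O)c4)c3)ccc2C1=O` gives 88.1%, a change of a number 24.8 percentage points higher from compound 1 to compound 2 (beyond the scatter). That step shows a larger response when a smaller group sits on this nitrogen, though it does not involve propyl or cyclopropyl directly, so its bearing on the present change is indirect. Since propyl and cyclopropyl are both small groups of the same atom count, no step beyond the scatter is expected. For compound 4 the estimated value in this assay is 85%, within a range of 65% to 105%.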

Compound 4, largest response reached (Emax), in percent of the reference or control that the assay uses: 64.9%
Compound 4: middle estimate off by 20.1 percentage points, on the high side, and the stated range ends above it.
By their numbers in this assay, from the lowest: compounds 1 and 4 (each within the scatter of the next); then compound 2.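

In this assay there is a number 23.2 percentage points lower from compound 2 to compound 4 (beyond the scatter), yet a number 1.6 percentage points higher from compound 1 to compound 4 (within the scatter), so cyclopropyl on this nitrogen matches cyclohexyl rather than isopropyl. The rise seen from compound 1 to compound 2 therefore does not extend to compound 4, and the response does not simply follow the size of the group across these three compounds. No measured evidence here explains the result. The step from compound 3 to compound 4 cannot be read, as compound 3 has no number. On these data alone, whether a straight chain such as ethyl or butyl on this nitrogen would respond like isopropyl or like cyclopropyl remains open.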